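This account rests on a few compounds, and the source may have more. Where it says the series, first, only, none or still open, it means among the compounds named here.

Of the compounds shown here, three have been tested in a functional assay on MCF7 cells (Homo sapiens) for cytotoxicity, read by sulforhodamine B assay; on this read-out higher numbers stand for an effect only at larger amounts of compound and lower numbers for an effect already at smaller amounts. Compound 1 `C=C1CC[C@@H]2[C@](C)(CO[Si](c3ccccc3)(c3ccccc3)C(C)(C)C)[C@H](OC(C)=O)CC[C@@]2(C)[C@@H]1C/C=C1/C(=O)OC[C@H]1O` gives 7.53 uM in this assay. Compound 2 `C=C1CC[C@@H]2[C@](C)(CO[Si](C)(C)C(C)(C)C)[C@H](OC(C)=O)CC[C@@]2(C)[C@@H]1C/C=C1/C(=O)OC[C@H]1OC(C)=O` gives 2.84 uM, and compound 3 `C=C1CC[C@@H]2[C@](C)(CO[Si](C)(C)C(C)(C)C)[C@H](O)CC[C@@]2(C)[C@@H]1C/C=C1/C(=O)OC[C@H]1OC(C)=O` gives 10.4 uM. Compound 3 and compound 2 differ by acetyl in place of hydrogen on an oxygen on a saturated carbon, and in this assay the step is a 3.7-fold lower number from compound 3 to compound 2 (0.56 log units; beyond the scatter). The difference between the core of compound 1 and the core of compound 3 is not broken down here. Compound 4 `C=C1CC[C@@H]2[C@](C)(CO[Si](c3ccccc3)(c3ccccc3)C(C)(C)C)[C@H](OC(C)=O)CC[C@@]2(C)[C@@H]1C/C=C1/C(=O)OC[C@H]1OC(C)=O` is not yet measured; it differs from compound 1 by acetyl in place of hydrogen on an oxygen on a saturated carbon, the same change seen from compound 3 to compound 2, at a place described in the same words. Because that earlier step was a 3.7-fold lower number from compound 3 to compound 2 (0.56 log units; beyond the scatter), a step of similar size is expected, a 3.8-fold lower number from compound 1 to compound 4 (0.58 log units; beyond the scatter). Compound 4 is therefore estimated to give 2 uM in this assay, most likely between 0.9 uM and 4.5 uM.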

Compound 4, concentration for half-maximal effect: 45.7 uM
Beside the measured number, compound 4's estimate is 23-fold (1.36 log units) below it; the measured number lies above the stated range.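

In this assay, acetyl in place of hydrogen on an oxygen on a saturated carbon gives a 6.1-fold higher number from compound 1 to compound 4 (0.78 log units; beyond the scatter), so the change does not carry over from one core to the other with the same direction or size: the same change on two cores in this assay, a 3.7-fold lower number (0.56 log units; beyond the scatter) from compound 3 to compound 2 and a 6.1-fold higher number (0.78 log units; beyond the scatter) from compound 1 to compound 4, 22-fold (1.35 log units) apart, beyond the scatter of two such steps. A step measured on one of these two cores is therefore a poor guide to the same change on the other. The steps do not show why they part, nor how the change would behave on any further core.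

The compounds shown leave open what other groups on that oxygen would do. A longer chain such as butanoyl, or a benzoyl group, might follow either core's step or neither.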